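Hydroxy to Nitro Swap Tested on a Second Core

The source may hold more compounds than are shown below. What is called first, only, known or untested is meant among the compounds shown, and "the series" means these compounds.

Compound 1 `COc1ccc(-c2cnnn2Cc2cc(OC)c(OC)c(OC)c2)cc1O` is tested in a functional assay on K562 cells (Homo sapiens) for cytotoxicity, read by MTT assay, with a stated time of 5 days (on this read-out lower numbers stand for stronger inhibition and higher numbers for weaker inhibition), and gives 530 nM. Compound 2 `COc1ccc(-c2cnnn2Cc2cc(OC)c(OC)c(OC)c2)cc1[N+](=O)[O-]` differs from it by nitro in place of hydroxy on an aromatic carbon. In this assay compound 2 reaches only a limit of the assay, > 10000 nM. This amounts to an at least 18-fold higher number from compound 1 to compound 2 (1.27 log units; beyond the scatter). Compound 3 `COc1ccc(Cn2cc(-c3cc(OC)c(OC)c(OC)c3)nn2)cc1O` is built from the same atoms as compound 1, joined differently; the difference between the two cores is not broken down here. In this assay compound 3 also reaches only a limit of the assay, > 10000 nM. Compound 4 `COc1ccc(Cn2cc(-c3cc(OC)c(OC)c(OC)c3)nn2)cc1[N+](=O)[O-]` has not yet been measured. It differs from compound 3 by nitro in place of hydroxy on an aromatic carbon, the same change that turned compound 1 into compound 2, made at the same place. Since compound 3 already sits at the limit of > 10000 nM in this assay, at which 2 of the 3 values shown sit, and the same change gave an at least 18-fold higher number from compound 1 to compound 2 (1.27 log units; beyond the scatter), compound 4 is expected to remain at or beyond that limit, an expected step that the limit leaves unreadable from compound 3 to compound 4. The estimate for compound 4 is 30000 nM, with an expected range from 10000 nM to 150000 nM.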

Compound 4, half-maximal inhibitory concentration: > 10000 nM
Compound 4 gave a limit, no number; the forecaster's own chance of this, stated with the estimate: 90%; the middle value is on the limit's open side.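

In this assay, compound 3 and compound 4 both give only a limit of the assay, so no step can be read between them: the limit of > 10000 nM in this assay, at which 3 of the 4 values shown sit. As far as these compounds go, whether nitro in place of hydroxy changes anything on the core of compound 3 stays open.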